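The source may hold more compounds than are shown below. What is called first, only, known or untested is meant among the compounds shown, and "the series" means these compounds.

Measured so far:
compound 1 `Cc1cnc(N)nc1-c1ccccc1`, 34%
compound 2 `Cc1ncc(C)c(-c2ccccc2)n1`, 12%
compound 3 `CC(C)(C)c1nc(N)ncc1-c1ccccc1`, 46%

All values come from a functional assay on the whole organism for inhibition, with Rattus norvegicus as the target, with stated times of 1 h and 3.5 h, at a dose of 100 mg/kg by the oral route; on this read-out lower numbers stand for less inhibition and higher numbers for more inhibition at the one dose given (going by the name of the read-out). Compound 3 stands highest of the three; compound 1 lies below it by a gap beyond the scatter, and compound 2 further below still. Going by the values given here, the one single-point change measured is methyl in place of amino on an aromatic carbon, which gave a number 22 percentage points lower from compound 1 to compound 2 (beyond the scatter). The difference between the core of compound 1 and the core of compound 3 is not broken down here.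

Compound 4 `Cc1ncc(-c2ccccc2)c(C(C)(C)C)n1` is not yet measured. It differs from compound 3 by methyl in place of amino on an aromatic carbon. This is the same kind of change as that from compound 1 to compound 2, though the surroundings differ: there the site is meta to a group of 6 heavy atoms and para to a methyl group, here meta to a tert-butyl group and para to a group of 6 heavy atoms. In this assay the step is expected to be a number 22 percentage points lower from compound 3 to compound 4 (beyond the scatter), a size resting on compound 1, whose step to compound 2 was a number 22 percentage points lower from compound 1 to compound 2 (beyond the scatter). Compound 4 is therefore estimated at 24%.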

Compound 4, a percentage reported as inhibition, in the whole organism at one dose (the size of the read-out at that dose, not a potency): 22%
The estimate for compound 4 lay 2 percentage points above the measured number; measured number inside the range.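

In this assay methyl in place of amino on an aromatic carbon gave a number 24 percentage points lower from compound 3 to compound 4 (beyond the scatter) and so matched the earlier step on the other core: the same change on two cores in this assay, a number 22 percentage points lower (beyond the scatter) from compound 1 to compound 2 and a number 24 percentage points lower (beyond the scatter) from compound 3 to compound 4, 2 percentage points apart, within the scatter of two such steps.

The transfer rests on two pairs only, so it holds for these two cores and does not establish that the step would be the same on a further core. Each number also comes from a single dose, so the pairs describe the size of the read-out at that dose and not a change in potency.

The compounds shown leave open how other groups at this site, such as hydroxyl, methoxy or dimethylamino, would compare with amino and methyl. Also open, as far as these compounds go, is what a longer chain or a carboxylic acid in place of the tert-butyl group would give.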